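Adding a Methoxy Group: Expected Cell Tolerance

The source may report more compounds than this note shows. Statements on the series, on what has been measured and on what is new or still open speak of the compounds shown alone.

Compound 1 `c1ccc(C[C@H](CCn2cncn2)c2ccccc2)cc1` gives 60.9 ug/mL in an ADME assay on HEp-2 cells (Homo sapiens) for cytotoxicity, read by MTT assay, with a stated time of 3 days; a higher number here means that more compound is tolerated, a lower number that less compound is tolerated.
Compound 2 `c1ccc(C[C@@H](CCn2cncn2)c2ccccc2)cc1` gives 55.9 ug/mL in this assay.

Compound 2 holds the lower of these two numbers, but the gap to compound 1 lies within the usual scatter, so the two cannot be told apart. The step of a 1.1-fold lower number from compound 1 to compound 2 (0.04 log units; within the scatter) goes with the fact that compounds 1 and 2 differ only in the configuration as drawn.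

Compound 3 `COc1ccc([C@H](CCn2cncn2)Cc2ccccc2)cc1` is not yet measured. It differs from compound 2 by methoxy in place of hydrogen on an aromatic carbon. Going by the values given here, no measured step here adds or removes a group on an aromatic ring; the only measured step, a 1.1-fold lower number from compound 1 to compound 2 (0.04 log units; within the scatter), concerns configuration alone and stayed within the scatter. There is therefore no measured basis for expecting a change beyond the scatter in this assay in either direction.

Compound 3 is expected to give about 55 ug/mL, likely between 28 ug/mL and 110 ug/mL. The estimate means an expected step of a 1.0-fold lower number from compound 2 to compound 3 (0.01 log units; within the scatter).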

Compound 3, half-maximal cytotoxic concentration: 60.3 ug/mL
Compound 3: the middle estimate sits 1.1-fold (0.04 log units) below what was measured; measured number inside the range.
By their numbers in this assay, from the lowest: compounds 2, 3 and 1 (each within the scatter of the next).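

In this assay, going by these compounds alone, the addition of methoxy gives a 1.1-fold higher number from compound 2 to compound 3 (0.03 log units; within the scatter) and so adds a first reading for this position: a group with an oxygen can replace hydrogen on an aromatic carbon, para to a large group, and compound 3 still cannot be told apart from compound 2. Until now, the only measured difference among these compounds was one of configuration, so this is the first sign that the ring itself can carry a substituent without a readable shift in this assay. Nothing available explains why this swap leaves the number within the scatter.

As far as these compounds go, whether an amine or a carboxylic acid on the same carbon would also stay within the scatter remains open. From the compounds shown here alone, it is also open whether methoxy would behave the same way on the core with the opposite configuration, as drawn in compound 1.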